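The source may hold more compounds than are shown below. What is called first, only, known or untested is meant among the compounds shown, and "the series" means these compounds.

Compound 3 `CC[C@@]1(c2ccccc2)OCC[C@@H](CCNCc2ccccc2)O1` gives 27 nM in an assay for displacement of a labelled ligand from Sigma non-opioid intracellular receptor 1 (Cavia porcellus), read by scintillation counting (a lower number here means a stronger inhibitor, a higher number a weaker inhibitor), which puts it highest of the two numbers in this assay; its nearest neighbour is compound 1 `c1ccc(CNCC[C@@H]2CCO[C@H](c3ccccc3)O2)cc1`, which gives 19 nM, and the gap between them, a 1.4-fold higher number from compound 1 to compound 3 (0.15 log units; within the scatter), is within the scatter. Compound 2 `CNCC[C@@H]1CCOC(c2ccccc2)(c2ccccc2)O1` returns only a limit of the assay, > 10000 nM, at which one of the three values sits (the limit of > 10000 nM in this assay, at which 1 of the 3 values shown sits).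

Compound 4 `CC[C@@]1(c2ccccc2)OCC[C@@H](CCCN)O1` is not yet measured. It differs from compound 3 by aminomethyl in place of benzylamino on a saturated chain carbon, two bonds along the chain from a saturated ring carbon. No measured step covers this change: the one step shown, a 1.4-fold higher number from compound 1 to compound 3 (0.15 log units; within the scatter), concerns an ethyl on the ring and was within the scatter, so it says nothing about the amine substituent. Compound 2 carries a methyl rather than a benzyl on the nitrogen but also differs at the ring, so its limit and the number for compound 3 cannot be read as a single step. With no benzyl left on the nitrogen, compound 4 is expected to show a markedly higher number, a step of a 74-fold higher number from compound 3 to compound 4 (1.87 log units; beyond the scatter) from compound 3 to compound 4. The estimate for compound 4 is 2000 nM, in the range 300 nM to 10000 nM.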

Compound 4, inhibition constant: 6450 nM
Beside the measured number, compound 4's estimate is 3.2-fold (0.51 log units) below it; the range from low to high includes it.
By their numbers in this assay, from the lowest: compounds 1 and 3 (each within the scatter of the next); then compound 4. At a limit, above all of these: compound 2.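

In this assay, aminomethyl in place of benzylamino on a saturated chain carbon, two bonds along the chain from a saturated ring carbon, gives a 240-fold higher number from compound 3 to compound 4 (2.38 log units; beyond the scatter), whereas the ethyl on the ring gave a 1.4-fold higher number from compound 1 to compound 3 (0.15 log units; within the scatter). Going by these compounds alone, this is the first step between compounds differing in one place that lies beyond the scatter, so the number responds strongly to the group at this chain position, and benzylamino is far better here than aminomethyl. No measurement shown gives a cause for this step.

The change removes the six-membered aromatic ring and the carbons that carry it together, so the contribution of the ring alone cannot be separated out. Going by these compounds, how methylamino, dimethylamino or phenethylamino would read at this position on the ethyl-bearing core remains open.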